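Amide variation on a shared anilinopyrimidine core

A few compounds are considered here, and "the series" means these few. Any claim that something is new, unique, unknown or untested is made for them only; others in the source may bear on it.

Compounds measured in a functional assay on LoVo cells (Homo sapiens) for inhibition, read by BrdU incorporation, with a stated time of 48 h; a lower number here means a stronger inhibitor, a higher number a weaker inhibitor:
compound 1, `CN[C@H]1CCN(C(=O)c2ccc(Nc3nccc(-c4cnc(C)n4C(C)C)n3)cc2)C1`, compound 1 gives 180 nM
compound 2, `Cc1ncc(-c2nc(Nc3ccc(C(=O)N4CCCN(C)CC4)cc3)ncc2F)n1C(C)C`, compound 2 gives 40 nM
compound 3, `Cc1ncc(-c2nc(Nc3ccc(C(=O)NC4CCN(C)CC4)cc3)ncc2F)n1C(C)C`, compound 3 gives 320 nM

For the measured compounds named here, compound 3 gives the highest number of the three in this assay, but its gap to compound 1 lies within the scatter; only compound 2 stands clearly apart, and the one step on record, an 8.0-fold higher number from compound 2 to compound 3 (0.90 log units; beyond the scatter), shows that exchanging the group on the carbonyl carbon moves the number well beyond the scatter. Compound 4, `CN[C@H]1CCN(C(=O)c2ccc(Nc3ncc(F)c(-c4cnc(C)n4C(C)C)n3)cc2)C1`, changes that same position again: 3-(methylamino)pyrrolidin-1-yl in place of (1-methylpiperidin-4-yl)amino on a carbonyl carbon. Compound 4 thus carries the amide group of compound 1 together with the fluorinated core of compound 3. Going by the values given here, no step between compound 1 and compound 4 is on record, so the only guide is that compound 1 and compound 3 differ within the scatter while the recorded amide exchange was modest in size. Compound 4 is therefore expected to give a somewhat lower number than compound 3, estimated as a 2.5-fold lower number from compound 3 to compound 4 (0.39 log units; beyond the scatter). The estimate for compound 4 in this assay is 130 nM, with a likely range from 50 nM to 350 nM.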

Compound 4, half-maximal inhibitory concentration: 39 nM
Beside the measured number, compound 4's estimate is 3.3-fold (0.52 log units) above it; the measured number lies below the stated range.
By their numbers in this assay, from the lowest: compounds 4 and 2 (each within the scatter of the next); then compounds 1 and 3 (each within the scatter of the next).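

In this assay an 8.2-fold lower number from compound 3 to compound 4 (0.91 log units; beyond the scatter) shows that on the fluorinated core, 3-(methylamino)pyrrolidin-1-yl in place of (1-methylpiperidin-4-yl)amino on a carbonyl carbon shifts the number beyond the scatter, much as the earlier exchange did. The a 1.0-fold lower number from compound 2 to compound 4 (0.01 log units; within the scatter) lies within the scatter, so 3-(methylamino)pyrrolidin-1-yl and 4-methyl-1,4-diazepan-1-yl cannot be told apart here, and of the three groups on this core only (1-methylpiperidin-4-yl)amino stands clearly apart. For the compounds shown here, the a 4.6-fold lower number from compound 1 to compound 4 (0.66 log units; beyond the scatter) gives the first reading of fluoro in place of hydrogen on an aromatic carbon with the amide group held the same, and that step lies beyond the scatter.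

No measurement offered here explains either step. Still open, on these data alone, are whether fluoro in place of hydrogen gives a similar step with the other amide groups, and how a chloro or methyl group in place of that fluoro, or an open-chain amine on the carbonyl carbon, would read.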